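This account rests on a few compounds, and the source may have more. Where it says the series, first, only, none or still open, it means among the compounds named here.

Measured compounds:
Compound 2, `CCn1cc(C(=O)O)c(=O)c2cc(F)c(N3CCN(/C=N/NC(=O)c4ccc(C(F)(F)F)cc4)CC3)cc21`: in an ADME assay on SH-SY5Y cells (Homo sapiens) for cytotoxicity, read by MTT assay (a lower number here means a stronger inhibitor, a higher number a weaker inhibitor), compound 2 gives 107000 nM.
Compound 1, `O=C(N/N=C/N1CCN(c2cc3c(cc2F)c(=O)c(C(=O)O)cn3C2CC2)CC1)c1cccc(F)c1`: in this assay compound 1 gives "not determined" (no result reported).

Going by the values given here, compound 2 stands alone on the numbers: its value is the only one reported in this assay, and compound 1 offers no figure to set beside it, so there is no measured step of any kind to lean on. Compound 3 `CCn1cc(C(=O)O)c(=O)c2cc(F)c(N3CCN(/C=N/NC(=O)c4cccc(F)c4)CC3)cc21` differs from compound 2 in a single place: 3-fluorophenyl in place of 4-(trifluoromethyl)phenyl on a carbonyl carbon. Among the compounds with values here, no measured pair shows this exchange, so its effect cannot be read from the data. The author expects compound 3 to stay close to compound 2, with a step of a 1.1-fold higher number from compound 2 to compound 3 (0.05 log units; within the scatter) that is not expected to reach beyond the usual scatter in either direction. For compound 3 the estimated value is 120000 nM, expected to fall between 40000 nM and 300000 nM.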

Compound 3, half-maximal inhibitory concentration: > 430000 nM
Compound 3: no number, only a limit (the forecaster's own chance of this, stated with the estimate: 30%); middle value at least 3.5-fold (0.55 log units) from the limit.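

Going by these compounds alone, on the carbonyl carbon, the exchange of 4-(trifluoromethyl)phenyl for 3-fluorophenyl gives the first measured step at this position: in this assay it amounts to an at least 4.0-fold higher number from compound 2 to compound 3 (0.60 log units; beyond the scatter), which shows that the group on this carbonyl carbon is not indifferent to the read-out and that this change moves it towards a weaker inhibitor. Compound 3 gives > 430000 nM, which is a limit of the assay and not a number. The step is therefore a lower bound on the change, and its full size is not fixed: the limit of > 430000 nM in this assay, at which 1 of the 3 values shown sits.

The compounds shown do not separate the loss of the trifluoromethyl group from the arrival of the fluorine. They also leave open how a plain phenyl, a methoxyphenyl or an amine on this carbonyl carbon would read out.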